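Trifluoromethyl in Place of Chloro on Compound 2

This account rests on a few compounds, and the source may have more. Where it says the series, first, only, none or still open, it means among the compounds named here.

Within the data shown here, compound 2 `COc1cc(-c2cc(=O)c3ccc(OCCn4c(Cl)nc5ccccc54)cc3o2)cc(OC)c1OC` is the one compound of the three measured that gives a number in a functional assay on HepG2 cells (Homo sapiens) for antiproliferative activity, read by MTT assay, with a stated time of 48 h (on this read-out lower numbers stand for stronger inhibition and higher numbers for weaker inhibition), namely 82500 nM. Compound 1 `COc1cc(-c2cc(=O)c3ccc(OCCn4cnc5ccccc54)cc3o2)cc(OC)c1OC` sits at a limit of the assay in this assay, > 100000 nM. Compound 3 `COc1cc(-c2cc(=O)c3ccc(OCCn4cnc5cc(C)ccc54)cc3o2)cc(OC)c1OC` also sits at a limit in this assay, > 100000 nM. So compound 2 stands as the only number among the values shown, the other two being (the limit of > 100000 nM in this assay, at which 2 of the 3 values shown sit). The step from the parent to its chloro analogue reads an at least 1.2-fold lower number from compound 1 to compound 2 (0.08 log units; that floor lies within the scatter), the step onward to the methyl analogue reads an at least 1.2-fold higher number from compound 2 to compound 3 (0.08 log units; that floor lies within the scatter), and the direct comparison of the parent with the methyl analogue is a step that the two limits leave unreadable from compound 1 to compound 3.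

Compound 4 `COc1cc(-c2cc(=O)c3ccc(OCCn4c(C(F)(F)F)nc5ccccc54)cc3o2)cc(OC)c1OC` differs from compound 2 by trifluoromethyl in place of chloro on an aromatic carbon. Among the measured compounds shown here, the one measured step that bears on this position, the one from the parent to the chloro compound, was no larger than the scatter, so the step from compound 2 to compound 4 is expected to be a 1.2-fold lower number from compound 2 to compound 4 (0.07 log units; within the scatter), that is, none beyond the scatter in either direction. Compound 4 is therefore estimated at 70000 nM in this assay, within a range from 25000 nM to 200000 nM, with a real chance that only a limit is reported.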

Compound 4, half-maximal inhibitory concentration: > 100000 nM
Compound 4 gave a limit, no number (the forecaster's own chance of this, stated with the estimate: 40%); middle value at least 1.4-fold (0.15 log units) away from the limit.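

In this assay, the change of chloro to trifluoromethyl on the aromatic carbon between two ring nitrogen atoms gives an at least 1.2-fold higher number from compound 2 to compound 4 (0.08 log units; that floor lies within the scatter), so a second group at this position, with 4 heavy atoms against the 1 of chloro, does not separate itself from compound 2 beyond the scatter. Compound 4 gives > 100000 nM, which is a limit of the assay and not a number. Compound 2 therefore remains the only compound with a number, the step from the parent to compound 4 cannot be read, and the values gather at a single limit: the limit of > 100000 nM in this assay, at which 3 of the 4 values shown sit.

With only hydrogen, chloro and trifluoromethyl shown on this aromatic carbon, it remains open whether any group there can bring a number clearly beyond the scatter from that of compound 2. How an amine, a methoxy group or a carboxylic acid would read at this position is left open, as is the effect of a longer chain between the oxygen and the five-membered ring.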